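From difluoromethoxy to hexyloxy: an estimate for compound 4

The source may hold more compounds than are shown below. What is called first, only, known or untested is meant among the compounds shown, and "the series" means these compounds.

Measured in a functional assay on MCF7 cells (Homo sapiens) for antiproliferative activity, read by sulforhodamine B assay, with a stated time of 48 h (on this read-out lower numbers stand for stronger inhibition and higher numbers for weaker inhibition), so far
Compound 1 `CCCCc1ccc(NS(=O)(=O)c2ccc(N3CCNC3=O)cc2)cc1` gives 770 nM in this test
Compound 2 `O=C1NCCN1c1ccc(S(=O)(=O)Nc2ccc(Cl)cc2)cc1` gives 170 nM in this test
Compound 3 `O=C1NCCN1c1ccc(S(=O)(=O)Nc2ccc(OC(F)F)cc2)cc1` gives 760 nM in this test

Compound 3 sits in the upper pair of these numbers, level with compound 1 within the usual scatter. Compound 2 is clearly the strongest of the three.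

Compound 4 `CCCCCCOc1ccc(NS(=O)(=O)c2ccc(N3CCNC3=O)cc2)cc1` has not yet been measured. It keeps the shared core and differs from compound 3 in one place. The change is hexyl in place of difluoromethyl on an oxygen on an aromatic ring and, cut one bond further out, it reads difluoromethoxy to hexyloxy.

Among the compounds with values here, no measured step makes this exact swap. The closest guide is a 1.0-fold lower number from compound 1 to compound 3 (0.01 log units; within the scatter) where difluoromethoxy replaces a butyl chain on an aromatic carbon and the number barely moves. The larger steps, a 4.5-fold lower number from compound 1 to compound 2 (0.66 log units; beyond the scatter) and a 4.5-fold higher number from compound 2 to compound 3 (0.65 log units; beyond the scatter) both involve chloro, which plays no part in this change. Within the data shown here, no other compound here carries a hexyl chain, so the range must stay wide.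

In this assay the expected result is a 1.3-fold higher number from compound 3 to compound 4 (0.12 log units; within the scatter) and so no step beyond the scatter. For compound 4 the estimated value is 1000 nM with an expected range from 350 nM to 4000 nM in this test.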

Compound 4, half-maximal inhibitory concentration: > 1000 nM
Compound 4: only a limit was reported; the forecaster's own chance of this, stated with the estimate: 5%; the middle value sits exactly at the limit.
By their numbers in this assay, from the lowest: compound 2; then compounds 3 and 1 (each within the scatter of the next). At a limit, above all of these: compound 4.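

In this assay compound 4 gives > 1000 nM, which is a limit of the assay and not a number: the limit of > 1000 nM in this assay, at which 1 of the 4 values shown sits. Read as floors, an at least 1.3-fold higher number from compound 3 to compound 4 (0.11 log units; that floor lies within the scatter) and an at least 1.2-fold higher number from compound 1 to compound 4 (0.11 log units; that floor lies within the scatter) both stay within the scatter, so the result does not yet separate hexyloxy from difluoromethoxy or from butyl in this place, though the true number could lie much higher. Within the data shown here, the one step that clears the scatter is an at least 5.8-fold higher number from compound 2 to compound 4 (0.76 log units; beyond the scatter), which shows that a hexyl chain on the oxygen does not match the chloro group and leaves compound 2 as the strongest of the four, now against a chain joined through oxygen as well as the butyl chain and the difluoromethoxy group.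

On these data alone, how far the number of compound 4 lies past its limit stays unknown, so the real size of all three steps is open. The compounds shown also leave open whether a shorter chain on the oxygen, such as methoxy or ethoxy, or a different group such as bromo or an amine, would bring the number down towards that of compound 2.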